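Coumarin-3-carboxamide series: nitro removal on the ethoxy anilide

The source may report more compounds than this note shows. Statements on the series, on what has been measured and on what is new or still open speak of the compounds shown alone.

Working notes on four anilides sharing one core. Compound 1 `Cc1noc(NS(=O)(=O)c2ccc(NC(=O)c3cc4ccccc4oc3=O)cc2)c1C` is measured in a functional assay on CCRF-CEM cells (Homo sapiens) for antiproliferative activity, read by fluorescence and resazurin assay, with a stated time of 48 h (on this read-out lower numbers stand for stronger inhibition and higher numbers for weaker inhibition), where compound 1 gives 26600 nM. Compound 2 `Cc1noc(NS(=O)(=O)c2ccc(NC(=O)c3cc4cc([N+](=O)[O-])ccc4oc3=O)cc2)c1C` carries a nitro group on the core; in this assay compound 2 gives 14300 nM. Compound 3 `CCOc1ccc(NC(=O)c2cc3cc([N+](=O)[O-])ccc3oc2=O)cc1` keeps that nitro group but differs from compound 2 in the anilide part: ethoxy in place of (3,4-dimethyl-1,2-oxazol-5-yl)sulfamoyl on an aromatic carbon. In this assay compound 3 gives 13200 nM, and the step is a 1.1-fold lower number from compound 2 to compound 3 (0.03 log units; within the scatter).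

The change from compound 2 to compound 1 is hydrogen in place of nitro on an aromatic carbon, and it gave a 1.9-fold higher number from compound 2 to compound 1 (0.27 log units; within the scatter). Compound 4 `CCOc1ccc(NC(=O)c2cc3ccccc3oc2=O)cc1` is not yet measured; it stands to compound 3 as compound 1 stands to compound 2: hydrogen in place of nitro on an aromatic carbon. The place descriptions of both changes agree word for word, so this is the same change made on the other anilide.

Among the measured compounds shown here, with only one earlier instance to rest on, the step from compound 3 to compound 4 is expected to be about a 1.9-fold higher number from compound 3 to compound 4 (0.28 log units; within the scatter), taken from the step measured from compound 2 to compound 1 a 1.9-fold higher number from compound 2 to compound 1 (0.27 log units; within the scatter). Compound 4 is therefore estimated at 25000 nM in this assay, expected to lie between 10000 nM and 60000 nM.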

Compound 4, half-maximal inhibitory concentration: 17900 nM
Compound 4: middle estimate off by 1.4-fold (0.15 log units), on the high side, within the range that was stated.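

In this assay, hydrogen in place of nitro on the ethoxy anilide gives a 1.4-fold higher number from compound 3 to compound 4 (0.13 log units; within the scatter), and set beside the same change on the (3,4-dimethyl-1,2-oxazol-5-yl)sulfamoyl anilide, the two steps agree: the same change on two cores in this assay, a 1.9-fold higher number (0.27 log units; within the scatter) from compound 2 to compound 1 and a 1.4-fold higher number (0.13 log units; within the scatter) from compound 3 to compound 4, 1.4-fold (0.14 log units) apart, within the scatter of two such steps. Across these two anilides the change therefore behaves alike, in that neither step lies beyond the scatter and the two steps do not differ from each other. This does not show that the nitro group matters to the read-out on either anilide, and two pairs give no rule for other anilides or a step size that could be relied on elsewhere.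

Going by these compounds, it remains open whether another group on the same aromatic carbon of the shared core, such as an amine or a carboxylic acid, would give a step beyond the scatter. Also open, on these data alone, is how the same change would read on an anilide with a longer alkoxy chain in place of ethoxy.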